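Fluoro Added to a Benzyloxy Group on Two Related Cores

The source may report more compounds than this note shows. Statements on the series, on what has been measured and on what is new or still open speak of the compounds shown alone.

The measured compounds, each in an ADME assay on RAW264.7 cells (Mus musculus) for cytotoxicity, read by MTT assay, with a stated time of 24 h, in the presence of a further agent that is not named here; on this read-out lower numbers stand for stronger inhibition and higher numbers for weaker inhibition:

Compound 1, `COc1cc(OC)c2c(c1)C(C(O)c1ccc(OCc3ccccc3)cc1)OC2=O`, gives > 40000 nM, which is a limit of the assay rather than a number.
Compound 2, `COc1cc(OC)c2c(c1)C(C(O)c1ccc(OCc3ccc(F)cc3)cc1)OC2=O`, gives > 40000 nM, again a limit.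
Compound 3, `COc1cc(OC)c2c(c1)/C(=C/c1ccc(OCc3ccccc3)cc1)OC2=O`, gives > 40000 nM, also a limit.

Compound 1 and compound 2 differ by one change, (fluoro in place of hydrogen on an aromatic carbon). The step that the two limits leave unreadable from compound 1 to compound 2 cannot be sized, because of the limit of > 40000 nM in this assay, at which 3 of the 3 values shown sit. How the core of compound 3 differs from the core of compound 1 is not broken down here.

Compound 4, `COc1cc(OC)c2c(c1)/C(=C/c1ccc(OCc3ccc(F)cc3)cc1)OC2=O`, is not yet measured. It differs from compound 3 by fluoro in place of hydrogen on an aromatic carbon, the same change that leads from compound 1 to compound 2, made in the same place on the same kind of ring.

Given that compound 1, compound 2 and compound 3 all sit at the limit, the step is expected to be a step that the limit leaves unreadable from compound 3 to compound 4, with compound 3 itself reading > 40000 nM as a limit. Compound 4 is therefore estimated to give 60000 nM in this assay, most likely again as a limit rather than a number.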

Compound 4, half-maximal inhibitory concentration: > 40000 nM
Compound 4 ended at the assay's limit; the forecaster's own chance of this, stated with the estimate: 85%; the middle value does not contradict the limit.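

No size can be read for the step from compound 3 to compound 4, because both compounds end at a limit rather than a number: the limit of > 40000 nM in this assay, at which 4 of the 4 values shown sit.

The compounds shown leave open whether fluoro in place of hydrogen makes any difference on either core, and how far compound 1, compound 2, compound 3 and compound 4 each lie beyond that limit.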